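The source may report more compounds than this note shows. Statements on the series, on what has been measured and on what is new or still open speak of the compounds shown alone.

Going by the values given here, in a functional assay on A2780 cells (Homo sapiens) for inhibition, read by MTT assay, with a stated time of 72 h (a lower number here means a stronger inhibitor of growth, a higher number a weaker inhibitor of growth), compound 2 `O=S(=O)(NCCCNCc1ccc(Cl)c(C(F)(F)F)c1)c1cc(C(F)(F)F)cc(C(F)(F)F)c1` stands at the higher of the two numbers measured so far, giving 5900 nM, while compound 1 `COc1ccc(CNCCCNS(=O)(=O)c2cc(C(F)(F)F)cc(C(F)(F)F)c2)cc1OC` gives 3800 nM. Compound 3 `O=S(=O)(NCCCNCC1COc2ccccc2O1)c1cc(C(F)(F)F)cc(C(F)(F)F)c1` differs from compound 2 in one place: 2,3-dihydro-1,4-benzodioxin-2-yl in place of 4-chloro-3-(trifluoromethyl)phenyl on a saturated chain carbon bound to an amine nitrogen. Among the compounds with values here, the one measured step that bears on this change, an exchange of the group on the same chain carbon, was a 1.6-fold higher number from compound 1 to compound 2 (0.19 log units; within the scatter), so a further exchange there is expected to move the number by no more than the scatter. Compound 3 is therefore expected to give about 4500 nM, between 1500 nM and 13000 nM. This estimate corresponds to a step of a 1.3-fold lower number from compound 2 to compound 3 (0.12 log units; within the scatter).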

Compound 3, concentration for 50% growth inhibition: 1500 nM
For compound 3 the middle estimate is 3.0-fold (0.48 log units) above the measured one; the measured number falls inside the stated range.
By their numbers in this assay, from the lowest: compound 3; then compounds 1 and 2 (each within the scatter of the next).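

The earlier exchange at this saturated chain carbon stayed within the scatter, but this one shows that the group there can change the result: 2,3-dihydro-1,4-benzodioxin-2-yl gives a 3.9-fold lower number from compound 2 to compound 3 (0.59 log units; beyond the scatter) and a 2.5-fold lower number from compound 1 to compound 3 (0.40 log units; beyond the scatter). Both steps are modest but beyond the scatter, making compound 3 the strongest growth inhibitor of the three. Nothing measured here gives a reason for this difference.

Going by these compounds, it remains open whether the non-aromatic ring or its two oxygens matter. It is also unknown whether a cyclohexyl group, a plain phenyl or a pyridine on this carbon would keep the lower number.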